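The source may report more compounds than this note shows. Statements on the series, on what has been measured and on what is new or still open speak of the compounds shown alone.

Working notes on the series. Three compounds share a common core and differ only in the aryl group on the urea nitrogen. Compound 1 `Cc1ccc(NC(=O)Nc2cccc(CNc3nccnc3Cl)c2)cc1` gives 9820 nM in a functional assay on T-24 cells (Homo sapiens) for antiproliferative activity, read by MTT assay, with a stated time of 48 h; a higher number here means a weaker inhibitor, a lower number a stronger inhibitor. Compound 2 `Cc1ccc(NC(=O)Nc2cccc(CNc3nccnc3Cl)c2)c(C)c1` gives 9230 nM in this assay, and the step of a 1.1-fold lower number from compound 1 to compound 2 (0.03 log units; within the scatter) lies within the scatter. Compound 3 `O=C(Nc1cccc(CNc2nccnc2Cl)c1)Nc1ccc(Cl)c(Cl)c1` gives 5210 nM in this assay; this is the lowest of the three numbers, but the steps leading to it, a 1.9-fold lower number from compound 1 to compound 3 (0.28 log units; within the scatter) and a 1.8-fold lower number from compound 2 to compound 3 (0.25 log units; within the scatter), both fall within the scatter, so compound 3 is not separable from compound 1 or compound 2 on the numbers shown.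

Compound 4 `COc1ccc(NC(=O)Nc2cccc(CNc3nccnc3Cl)c2)cc1` has not been measured. It differs from compound 3 by 4-methoxyphenyl in place of 3,4-dichlorophenyl on an amide-type nitrogen. Going by the values given here, the steps that bear on this change are the two earlier aryl swaps on the same amide-type nitrogen, a 1.9-fold lower number from compound 1 to compound 3 (0.28 log units; within the scatter) and a 1.8-fold lower number from compound 2 to compound 3 (0.25 log units; within the scatter), neither beyond the scatter. No step beyond the scatter is therefore expected in this assay; the expected step is a 1.7-fold higher number from compound 3 to compound 4 (0.24 log units; within the scatter). Compound 4 is estimated at 9000 nM, with a range from 4000 nM to 20000 nM.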

Compound 4, half-maximal inhibitory concentration: 9820 nM
Estimate against measurement, compound 4: 1.1-fold (0.04 log units) below; measured number inside the range.
By their numbers in this assay, from the lowest: compounds 3, 2, 1 and 4 (each within the scatter of the next).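

Replacing 3,4-dichlorophenyl with 4-methoxyphenyl on the amide-type nitrogen removes both chlorine atoms and adds a hydrogen-bond acceptor, yet in this assay the result is a 1.9-fold higher number from compound 3 to compound 4 (0.28 log units; within the scatter). The other two comparisons, a 1.1-fold higher number from compound 2 to compound 4 (0.03 log units; within the scatter) and no change at the digits printed from compound 1 to compound 4 (within the scatter), show that methoxy in place of methyl and 4-methoxyphenyl in place of 2,4-dimethylphenyl also leave the number within the scatter, so all four aryl groups now remain inseparable at this position. No measurement on hand bears on why this position tolerates these changes.

Still open, as far as these compounds go, is whether any group on this nitrogen can produce a step beyond the scatter, such as a phenyl carrying a carboxylic acid or a dimethylamino group, or a longer chain in place of the aryl ring. The compounds shown also leave open how the number responds to changes elsewhere, such as an amine in place of the chlorine on the shared core.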